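Catechol Replaced by Hydroxybenzyl Ether in a Biaryl Sulfonamide Series

A few compounds are considered here, and "the series" means these few. Any claim that something is new, unique, unknown or untested is made for them only; others in the source may bear on it.

Of the compounds shown here, three from this set have been measured in a functional assay on RS4-11 cells (Homo sapiens) for inhibition, read by CCK-8 assay, with a stated time of 48 h; a higher number here means a weaker inhibitor, a lower number a stronger inhibitor. Compound 1 `O=C(NCCNS(=O)(=O)c1ccc(-c2ccccc2Oc2ccc(O)c(O)c2)s1)Nc1cc(Cl)cc(Cl)c1` gives 4500 nM and stands lowest of the three. Compound 2 `O=[N+]([O-])c1ccc(Oc2ccc(O)c(O)c2)c(-c2ccsc2S(=O)(=O)N2CCN(C(=S)Nc3cc(C(F)(F)F)cc(C(F)(F)F)c3)CC2)c1` gives 9500 nM, and compound 3 `Cc1ccc(-c2ccsc2S(=O)(=O)NCCNC(=O)Nc2cccc([N+](=O)[O-])c2)c(Oc2ccc(O)c(O)c2)c1` gives 9100 nM. For the measured compounds named here, both of these lie beyond the scatter from compound 1, so compound 1 is the strongest inhibitor among the measured compounds, though the three differ from one another in several places at once, and no step between them can be traced to a single change.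

Compound 4 `O=C(NCCNS(=O)(=O)c1ccc(-c2ccccc2OCc2cccc(O)c2)s1)Nc1cc(Cl)cc(Cl)c1` has not yet been measured. It differs from compound 1 in one place only: 3-hydroxybenzyl in place of 3,4-dihydroxyphenyl on an oxygen on an aromatic ring. The change removes one hydrogen-bond donor and one hydrogen-bond acceptor and lengthens the link by a single carbon. Going by the values given here, no measured pair in this set shows what such a change does in this assay, so the expectation rests on compound 1 alone.

Since compound 1 gives 4500 nM and the measured compounds stay within a narrow band, a modest weakening is expected, a step of a 2.0-fold higher number from compound 1 to compound 4 (0.30 log units; within the scatter) from compound 1 to compound 4. Compound 4 is estimated at 9000 nM, with a range from 3000 nM to 30000 nM.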

Compound 4, half-maximal inhibitory concentration: > 50000 nM
Compound 4 gave a limit, no number (the forecaster's own chance of this, stated with the estimate: 10%); middle value at least 5.5-fold (0.74 log units) from the limit.
By their numbers in this assay, from the lowest: compound 1; then compounds 3 and 2 (each within the scatter of the next). At a limit, above all of these: compound 4.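

In this assay compound 4 stands as a limit and not a number, at > 50000 nM. For the compounds shown here, putting 3-hydroxybenzyl in place of 3,4-dihydroxyphenyl on an oxygen on an aromatic ring, with the rest of compound 1 unchanged, is the only single-place change in the set, and it gives an at least 11-fold higher number from compound 1 to compound 4 (1.04 log units; beyond the scatter), which shows that activity is sensitive to the group held on this oxygen. Going by these compounds alone, compounds 1, 2 and 3 all carry 3,4-dihydroxyphenyl there, so they could not show this, and the one compound without that group is the one that sits at the limit: the limit of > 50000 nM in this assay, at which 1 of the 4 values shown sits.

The change removes a hydroxyl and adds a carbon to the link at once, and the compounds shown do not tell which of the two accounts for the loss, nor how far beyond the limit compound 4 really lies. A 3-hydroxyphenyl group or a 3,4-dihydroxybenzyl group on the same oxygen would separate the two, and neither is among the compounds shown.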